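The compounds below may be only part of what the source reports. "The series", "measured", "known", "first", "only" and "open" are said of these compounds alone.

Among the measured compounds shown here, compound 2 `N#C[Se]c1ccc(NC(=O)Oc2ccc(Cl)cc2)cc1` and compound 1 `CCCCCCOC(=O)Nc1ccc([Se]C#N)cc1` are the two compounds measured so far in a functional assay on HT-29 cells (Homo sapiens) for cytotoxicity, read by MTT assay, with a stated time of 72 h; a lower number here means a stronger inhibitor of growth, a higher number a weaker inhibitor of growth. In this assay compound 2 gives 11800 nM, and compound 1 gives 10700 nM; the gap between these two numbers lies within the usual scatter, so neither stands apart from the other. Compound 3 `N#C[Se]c1ccc(NC(=O)Oc2ccccc2)cc1` has not yet been measured in this assay. It differs from compound 2 by hydrogen in place of chloro on an aromatic carbon. For the measured compounds named here, no comparable step exists among the measured compounds, and a change this small is expected to make no difference beyond the scatter. Compound 3 is therefore expected to give 12000 nM in this assay, within 5000 nM to 30000 nM. For compound 3 the expected step is a 1.0-fold higher number from compound 2 to compound 3 (0.01 log units; within the scatter).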

Compound 3, concentration for 50% growth inhibition: 11700 nM
Compound 3: the middle estimate sits 1.0-fold (0.01 log units) above what was measured; measured number inside the range.
By their numbers in this assay, from the lowest: compounds 1, 3 and 2 (each within the scatter of the next).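

In this assay, among the compounds shown here, hydrogen in place of chloro on the aromatic carbon gives no readable change (a 1.0-fold lower number from compound 2 to compound 3 (0.00 log units; within the scatter)), so this position so far tolerates losing the chloro. Phenyl in place of hexyl on the oxygen next to the carbonyl group is also a change that cannot be read (a 1.1-fold higher number from compound 1 to compound 3 (0.04 log units; within the scatter)), even though an aromatic ring replaces a chain. Nothing measured here bears on what lies behind these results. From the compounds shown here alone, whether an amine or a carboxylic acid on that aromatic carbon, or a longer chain on that oxygen, would shift the number remains open.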